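Adding dimethylamino to compound 3

The source may report more compounds than this note shows. Statements on the series, on what has been measured and on what is new or still open speak of the compounds shown alone.

In a functional assay on MDA-MB-231 cells (Homo sapiens) for cytotoxicity, read by MTT assay, with a stated time of 24 h (on this read-out higher numbers stand for weaker inhibition and lower numbers for stronger inhibition), compound 1 `c1ccc(-c2nc3cccnc3n2C2CCCC2)cc1` gives 3000 nM, and compound 2 `Fc1ccc(-c2nc3cccnc3n2C2CCCC2)cc1` gives 500 nM. Compound 3 `c1cnc2c(c1)nc(-c1cncnc1)n2C1CCCC1` is known only as a limit, > 10000 nM. Compound 4 `CN(C)c1ncc(-c2nc3cccnc3n2C2CCCC2)cn1` differs from it by dimethylamino in place of hydrogen on an aromatic carbon, between two ring nitrogen atoms and para to a large group. For the measured compounds named here, the nearest precedent is fluoro in place of hydrogen, a 6.0-fold lower number from compound 1 to compound 2 (0.78 log units; beyond the scatter), a modest step. Pyrimidin-5-yl in place of an aryl group gave an at least 3.3-fold higher number from compound 1 to compound 3 (0.52 log units; beyond the scatter) and an at least 20-fold higher number from compound 2 to compound 3 (1.30 log units; beyond the scatter), so there is room to recover. A modest move towards a lower number in this assay is expected, and the estimated step is an at least 2.5-fold lower number from compound 3 to compound 4 (0.39 log units; beyond the scatter). For compound 4 the expected value is 4000 nM, within an estimated range of 700 nM to 20000 nM.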

Compound 4, half-maximal inhibitory concentration: 45 nM
The estimate for compound 4 lay 89-fold (1.95 log units) above the measured number, outside the stated range (below it).
By their numbers in this assay, from the lowest: compound 4; then compound 2; then compound 1. At a limit, above all of these: compound 3.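

In this assay, the place between two ring nitrogen atoms and para to a large group proves highly responsive: dimethylamino in place of hydrogen gives an at least 220-fold lower number from compound 3 to compound 4 (2.34 log units; beyond the scatter). The pyrimidin-5-yl group, which had given an at least 20-fold higher number from compound 2 to compound 3 (1.30 log units; beyond the scatter), therefore does not preclude low numbers once it carries dimethylamino. The printed step is only a lower bound, since compound 3 is known solely as a limit: the limit of > 10000 nM in this assay, at which 1 of the 4 values shown sits.

On these data alone, it remains open whether a primary amine, morpholine or methoxy in the same place would act similarly. Also open, as far as these compounds go, is whether dimethylamino on the phenyl group of compound 1 would give a comparable step.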